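A Chlorine-for-Fluorine Swap on the Benzyl Side

A few compounds are considered here, and "the series" means these few. Any claim that something is new, unique, unknown or untested is made for them only; others in the source may bear on it.

Measured in a functional assay on MT4 cells (Homo sapiens) for cytotoxicity, read by MTT assay; a lower number here means that less compound is tolerated, a higher number that more compound is tolerated:
- Compound 1 `Cc1c(O)nc(Sc2ccc(F)cc2F)nc1Cc1c(F)cccc1F` gives > 65800 nM, which is a limit
- Compound 2 `COc1ccc(Sc2nc(O)c(C)c(Cc3c(F)cccc3F)n2)cc1` gives 57500 nM

Among the compounds with values here, compound 2 carries the only actual number in the set. For compound 1 there is only (the limit of > 65800 nM in this assay, at which 1 of the 2 values shown sits). The next structure, compound 3 `COc1ccc(Sc2nc(O)c(C)c(Cc3c(Cl)cccc3Cl)n2)cc1`, differs from compound 2 as follows: 2,6-dichlorophenyl in place of 2,6-difluorophenyl on a saturated chain carbon bound to an aromatic carbon. Within the data shown here, the single measured step, an at least 1.1-fold lower number from compound 1 to compound 2 (0.05 log units; that floor lies within the scatter), lies at a different place and stays within the scatter. No step beyond the scatter is therefore expected in this assay. The expected change is a 1.3-fold lower number from compound 2 to compound 3 (0.11 log units; within the scatter). For compound 3 the estimated value is 45000 nM, with an expected range from 18000 nM to 85000 nM.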

Compound 3, half-maximal cytotoxic concentration: > 61400 nM
Compound 3 gave a limit, no number; the forecaster's own chance of this, stated with the estimate: 35%; at least 1.3-fold (0.13 log units) between middle value and limit.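

In this assay, the change on a saturated chain carbon bound to an aromatic carbon, the only one shown at this place, gives an at least 1.0-fold higher number from compound 2 to compound 3 (0.02 log units; that floor lies within the scatter). With 2,6-dichlorophenyl as with 2,6-difluorophenyl, no step beyond the scatter appears at this place. Compound 3 gives a limit and not a number, and the full size of this step stays unknown: the limit of > 61400 nM in this assay, at which 1 of the 3 values shown sits.

The compounds shown leave open how this assay responds when an amine or a carboxylic acid stands on the 2,6-dichlorophenyl ring. They also leave open what a longer chain would do at this saturated carbon.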